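Extending a Hydroxylated Chain: From Compound 3 to Compound 4

The compounds below may be only part of what the source reports. "The series", "measured", "known", "first", "only" and "open" are said of these compounds alone.

Of the compounds shown here, three sharing one core have been tested in an assay on isolated protein for inhibition of leukotriene B4 receptor 1 (Homo sapiens), tested at 10 uM; a lower number here means less inhibition, a higher number more inhibition at the concentration tested (going by the name of the read-out). Compound 1 `C=CCc1cc(C(C)=O)c(O)cc1OCCCC` gives 32%, compound 2 `C=CCc1cc(C(C)=O)c(O)cc1OCCCCCC` gives 50%, and compound 3 `C=CCc1cc(C(C)=O)c(O)cc1OCCCCO` gives 48%. Compound 3 thus stands second highest of the three: its gap to compound 2 lies within the scatter, while its gap to compound 1 lies beyond it. Compound 4 `C=CCc1cc(C(C)=O)c(O)cc1OCCCCCC(C)(C)O` differs from compound 3 in one place: 2-hydroxy-2-methylpropyl in place of hydroxy on a saturated chain carbon, four bonds along the chain from an oxygen on an aromatic ring. Among the compounds with values here, two measured steps bear on this change. Extending the chain by an ethyl gave a number 18 percentage points higher from compound 1 to compound 2 (beyond the scatter), and adding a hydroxy gave a number 16 percentage points higher from compound 1 to compound 3 (beyond the scatter), whereas exchanging ethyl for hydroxy produced a number 2 percentage points lower from compound 2 to compound 3 (within the scatter). For compound 4, which keeps a hydroxy and carries a longer chain than compound 3, a modest rise is expected, a number 10 percentage points higher from compound 3 to compound 4 (within the scatter). Compound 4 is therefore estimated at 58% in this assay, with a range from 40% to 75%.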

Compound 4, a percentage reported as inhibition, at one concentration (the size of the read-out at that concentration, not a potency): 98%
The estimate for compound 4 lay 40 percentage points below the measured number, outside the stated range (above it).
By their numbers in this assay, from the lowest: compound 1; then compounds 3 and 2 (each within the scatter of the next); then compound 4.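

In this assay, within the data shown here, the earlier compounds showed only modest steps, with a longer chain and a hydroxy each giving a similar rise, whereas the 2-hydroxy-2-methylpropyl group in place of hydroxy gives a number 50 percentage points higher from compound 3 to compound 4 (beyond the scatter). At the next position out, five bonds along the chain from the oxygen on the aromatic ring, 1-hydroxy-1-methylethyl in place of methyl gives a number 48 percentage points higher from compound 2 to compound 4 (beyond the scatter), and against the shared starting point the full change gives a number 66 percentage points higher from compound 1 to compound 4 (beyond the scatter), so a longer chain and a hydroxy together in one group reach far beyond either change alone. No available evidence explains the size of this rise.

The compounds shown leave open whether the two methyl groups of this group matter, since a straight chain ending in hydroxymethyl is not among them. They also leave open how an amine or a carboxylic acid at the end of this chain would compare.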